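Fluorobenzyl series: from 3-fluorophenyl to 4-fluorophenyl

The source may hold more compounds than are shown below. What is called first, only, known or untested is meant among the compounds shown, and "the series" means these compounds.

Measured so far in a functional assay on CCRF-CEM cells (Homo sapiens) for antiproliferative activity, with a stated time of 72 h (a higher number here means a weaker inhibitor, a lower number a stronger inhibitor), as follows
- compound 1 `OC[C@H]1O[C@@H](n2cnc3c(NCc4ccccc4F)ncnc32)[C@H](O)[C@@H]1O` gives 4600 nM
- compound 2 `OC[C@H]1O[C@@H](n2cnc3c(NCc4cccc(F)c4)ncnc32)[C@H](O)[C@@H]1O` gives 4000 nM

Compound 2 (4000 nM) stands level with compound 1 (4600 nM), as the two values lie within the scatter of each other and give no order. The next member is compound 3 `OC[C@H]1O[C@@H](n2cnc3c(NCc4ccc(F)cc4)ncnc32)[C@H](O)[C@@H]1O`, with 4-fluorophenyl in place of 3-fluorophenyl on a saturated chain carbon bound to a nitrogen on an aromatic ring. Within the data shown here, only one measured step bears on this change, namely a 1.2-fold lower number from compound 1 to compound 2 (0.06 log units; within the scatter) for the swap of 2-fluorophenyl for 3-fluorophenyl at the same place. That step stays within the scatter, so moving the fluorine has not yet shown any effect on this assay. Among the measured compounds shown here, no measured compound carries 4-fluorophenyl, and a single step is thin support. The expected step is therefore none beyond the scatter (no change at the digits printed from compound 2 to compound 3 (within the scatter)). The estimate for compound 3 is 4000 nM (expected range 2000 nM to 8000 nM)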

Compound 3, half-maximal inhibitory concentration: 1250 nM
The estimate for compound 3 lay 3.2-fold (0.51 log units) above the measured number, and the stated range ends above it.
By their numbers in this assay, from the lowest: compound 3; then compounds 2 and 1 (each within the scatter of the next).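

In this assay the place of the fluorine now matters: on a saturated chain carbon bound to a nitrogen on an aromatic ring, 4-fluorophenyl separates from both other isomers, with a 3.2-fold lower number from compound 2 to compound 3 (0.51 log units; beyond the scatter) and a 3.7-fold lower number from compound 1 to compound 3 (0.57 log units; beyond the scatter) while 2-fluorophenyl and 3-fluorophenyl gave no order. Both steps are modest, yet compound 3 is the strongest of these three compounds, and the groups exchanged have the same heavy atoms and the same counts, so among these compounds the difference goes with the arrangement of those atoms alone. Nothing measured here accounts for the result with 4-fluorophenyl.

The compounds shown leave open whether fluorine itself contributes to this result, since a plain phenyl, 4-chlorophenyl or 4-methoxyphenyl at the same place would be needed to separate the effect of the atom from that of the place it occupies. As far as these compounds go, it also remains open whether the order of the three isomers would hold with a longer chain joining the aromatic ring to the nitrogen.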